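From Benzyl to Indolyl: Expecting Little Change

The source may hold more compounds than are shown below. What is called first, only, known or untested is meant among the compounds shown, and "the series" means these compounds.

Measured so far:
compound 1, `CCCCCCCCCCCCCCCCCCNC(=O)[C@H]1CSC(CCCCCCCCCCCC)N1`: 8900 nM
compound 2, `CCCCCCCCCCCCCCCCCCNC(=O)[C@H]1CSC(Cc2ccccc2)N1`: 15300 nM

Of the compounds shown here, two have been measured in a functional assay on DU-145 cells (Homo sapiens) for antiproliferative activity, read by sulforhodamine B assay; on this read-out higher numbers stand for weaker inhibition and lower numbers for stronger inhibition. Compound 1 `CCCCCCCCCCCCCCCCCCNC(=O)[C@H]1CSC(CCCCCCCCCCCC)N1` gives 8900 nM, and compound 2 `CCCCCCCCCCCCCCCCCCNC(=O)[C@H]1CSC(Cc2ccccc2)N1` gives 15300 nM. Compound 2 holds the highest of the two numbers, with compound 1 as its nearest neighbour, and the step from one to the other, a 1.7-fold higher number from compound 1 to compound 2 (0.24 log units; within the scatter), is too small to tell the two apart on this read-out.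

Compound 3 `CCCCCCCCCCCCCCCCCCNC(=O)[C@H]1CSC(c2c[nH]c3ccccc23)N1` has not yet been measured. It differs from compound 2 in one place: 1H-indol-3-yl in place of benzyl on a saturated ring carbon. Within the data shown here, only one measured step exists, a 1.7-fold higher number from compound 1 to compound 2 (0.24 log units; within the scatter), which changed the same place but exchanged a different pair of groups and stayed within the scatter. Among the measured compounds shown here, no measured step tests the indol-3-yl group itself. On that slim basis, the expected step in this assay is none beyond the scatter, in either direction, with wide uncertainty. The estimate for compound 3 is 15000 nM, with a range from 5000 nM to 45000 nM. This corresponds to an expected step of a 1.0-fold lower number from compound 2 to compound 3 (0.01 log units; within the scatter).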

Compound 3, half-maximal inhibitory concentration: 8900 nM
The estimate for compound 3 lay 1.7-fold (0.23 log units) above the measured number; measured number inside the range.
By their numbers in this assay, from the lowest: compounds 1, 3 and 2 (each within the scatter of the next).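

In this assay, among these compounds, 1H-indol-3-yl in place of benzyl on the saturated ring carbon gives a 1.7-fold lower number from compound 2 to compound 3 (0.24 log units; within the scatter) and so, for the first time at this place, brings in a hydrogen-bond donor and a five-membered aromatic ring with a hetero atom, without a step beyond the scatter. The same group in place of dodecyl gives no change at the digits printed from compound 1 to compound 3 (within the scatter) and shows that, on this read-out, a long saturated chain and this two-ring aromatic group cannot be told apart here, just as benzyl could not be told apart from either of them. Nothing among the data given explains why these different groups end up so close together.

Going by these compounds, these three compounds therefore show no group at this place that moves the number beyond the scatter, so it remains unknown whether this position responds to changes of any kind in this assay. A carboxylic acid or an amine on this ring carbon, or a much shorter chain such as methyl, would test that more sharply than another large carbon-rich group.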